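Extending the acid of a thiazole aniline agonist

The compounds below may be only part of what the source reports. "The series", "measured", "known", "first", "only" and "open" are said of these compounds alone.

Compound 1 `Cc1nc(-c2ccc(C(F)(F)F)cc2)sc1CNc1ccc(C(=O)O)cc1` reaches 10% in a functional assay on CHO cells for agonist activity at Free fatty acid receptor 1 (Homo sapiens), read by a luciferase reporter (a lower number here means a smaller maximal response, a higher number a larger maximal response), the lowest of the two single numbers seen: compound 2 `O=C(O)CSc1ccc(NCc2cccc(Oc3ccccc3)c2)cc1` reaches 84%, higher by a gap beyond the scatter, while compound 3 `O=C(O)[C@H]1C[C@@H]1c1ccc(NCc2cccc(Oc3ccccc3)c2)cc1` gives 88%; 72% (2 entries) across its entries (the several entries of compound 3 in this assay, 88%; 72% (2 entries)). Compound 4 `Cc1nc(-c2ccc(C(F)(F)F)cc2)sc1CNc1ccc(CC(C)C(=O)O)cc1` differs from compound 1 by one change, (2-carboxypropyl in place of carboxy on an aromatic carbon). Compound 4 is expected to behave like compounds 2 and 3 rather than compound 1, because compound 2 gives 84% with an acid that is not joined straight to the ring. A large rise is therefore expected, a number 68 percentage points higher from compound 1 to compound 4 (beyond the scatter), well beyond the scatter. For compound 4 the estimate is 78%, from 50% to 105%.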

Compound 4, largest response reached (reported as percent of maximum), in percent of the reference or control that the assay uses: 100%
Estimate against measurement, compound 4: 22 percentage points below, within the range that was stated.
By their numbers in this assay, from the lowest: compound 1; then compound 2; then compound 4.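

In this assay, 2-carboxypropyl in place of carboxy on an aromatic carbon, para to a large group, gives a number 90 percentage points higher from compound 1 to compound 4 (beyond the scatter). Both groups carry one hydrogen-bond donor and one hydrogen-bond acceptor, and the heavy atoms added are all carbon, so this large step comes with a longer carbon chain on the acid and no change in those counts. Nothing in hand explains the rise.

The compounds shown leave open how much of the step belongs to the methyl branch rather than the chain length, which a plain 2-carboxyethyl group at this position would separate.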